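This account rests on a few compounds, and the source may have more. Where it says the series, first, only, none or still open, it means among the compounds named here.

Among the compounds with values here, in an ADME assay (liver) for metabolic stability, with Liver microsome (Rattus norvegicus) as the target, read by LC-MS, using microsomes, with a stated time of 5 min, tested at 1 uM (on this read-out lower numbers stand for slow clearance and higher numbers for fast clearance), compound 1 `O=C(c1cc(-n2ccc3ccccc32)c(O)cc1O)N1Cc2ccccc2C1` gives 25 mL.min-1.g-1, the higher of the two numbers measured so far, while compound 2 `O=C(c1cc(-n2ccc3c([N+](=O)[O-])cccc32)c(O)cc1O)N1Cc2ccccc2C1` gives 6 mL.min-1.g-1. Compound 3 `O=C(c1cc(-n2ccc3cc(Br)ccc32)c(O)cc1O)N1Cc2ccccc2C1` keeps the core of compound 1 and differs by one change: bromo in place of hydrogen on an aromatic carbon. Within the data shown here, the only measured step that bears on it is a 4.2-fold lower number from compound 1 to compound 2 (0.62 log units; beyond the scatter), a modest one with nitro in place of hydrogen on an aromatic carbon. This single step offers thin support, so a lower number is expected, by a somewhat smaller step. The expected step is a 2.1-fold lower number from compound 1 to compound 3 (0.32 log units; beyond the scatter). Compound 3 is estimated at 12 mL.min-1.g-1, with an expected range of 5 mL.min-1.g-1 to 28 mL.min-1.g-1.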

Compound 3, intrinsic clearance in microsomes: 16 mL.min-1.g-1
Beside the measured number, compound 3's estimate is 1.3-fold (0.12 log units) below it; the range from low to high includes it.
By their numbers in this assay, from the lowest: compound 2; then compounds 3 and 1 (each within the scatter of the next).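

In this assay, the step with bromo in place of hydrogen, a 1.6-fold lower number from compound 1 to compound 3 (0.19 log units; within the scatter), stays within the scatter, so this change on this aromatic carbon leaves compound 3 not distinguishable from compound 1. The nitro step, a 4.2-fold lower number from compound 1 to compound 2 (0.62 log units; beyond the scatter), therefore does not extend to every replacement of hydrogen on the six-membered aromatic ring. Nothing available gives a reason for this result. 

Still open, as far as these compounds go, is how a methoxy group or an amine on this same carbon would read, and whether bromo on another carbon of that ring would read the same.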